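Sulfonate esters of an imidazolylmethylphenol as lyase inhibitors

The compounds below may be only part of what the source reports. "The series", "measured", "known", "first", "only" and "open" are said of these compounds alone.

Measured compounds:
compound 1, `Ic1ccc(Cn2ccnc2)cc1`, 164 nM
compound 2, `CCc1ccc(S(=O)(=O)Oc2ccc(Cn3ccnc3)cc2)cc1`, 20 nM

Of the compounds shown here, two have been measured in an assay for inhibition of steroid 17-alpha-hydroxylase/17,20 lyase (Rattus norvegicus), using microsomes; a lower number here means a stronger inhibitor, a higher number a weaker inhibitor. Compound 1, `Ic1ccc(Cn2ccnc2)cc1`, gives 164 nM in this assay. Compound 2, `CCc1ccc(S(=O)(=O)Oc2ccc(Cn3ccnc3)cc2)cc1`, carries a sulfonate ester on the shared core and gives 20 nM in this assay. Compound 2 therefore stands at the lowest number of the two; its nearest neighbour is compound 1, whose number is higher by a margin beyond the usual scatter.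

The step now considered leads from compound 2 to compound 3, `O=S(=O)(Oc1ccc(Cn2ccnc2)cc1)c1ccc(C(F)(F)F)cc1`. The change is trifluoromethyl in place of ethyl on an aromatic carbon. For the measured compounds named here, there is no measured pair in this set that shows what such a swap does, so the expectation rests on compound 2 alone. In this assay the sulfonate ester of compound 2 sits at 20 nM, and the exchanged group is a small substituent away from the part that differs between compound 1 and compound 2. The step from compound 2 to compound 3 is expected to be small, with no direction that clearly exceeds the scatter, as a 1.3-fold higher number from compound 2 to compound 3 (0.10 log units; within the scatter). For compound 3 the estimate in this assay is 25 nM, with a likely range from 8 nM to 80 nM.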

Compound 3, half-maximal inhibitory concentration: 34 nM
Compound 3: middle estimate off by 1.4-fold (0.13 log units), on the low side, and the stated range covers the measured number.
By their numbers in this assay, from the lowest: compounds 2 and 3 (each within the scatter of the next); then compound 1.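

In this assay, trifluoromethyl in place of ethyl on an aromatic carbon, para to a large group, gives a 1.7-fold higher number from compound 2 to compound 3 (0.23 log units; within the scatter). For the compounds shown here, this is the first measured exchange at this position, and it shows that the two groups cannot be told apart in this assay, although they differ in size and in their atoms. The number therefore stays within the scatter with either group on this carbon, but no available evidence bears on why these two groups read alike.

The compounds shown leave open how an amine, a carboxylic acid or a longer chain on this same carbon would read in this assay, so the limits of what the position accepts remain unknown. They also leave open what a plain hydrogen on this carbon would give, and with it whether ethyl or trifluoromethyl contributes anything to the numbers of the sulfonate esters at all.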